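Ester to ether at the side-chain oxygen of the shared core

A few compounds are considered here, and "the series" means these few. Any claim that something is new, unique, unknown or untested is made for them only; others in the source may bear on it.

Compound 3 `CC[C@](C)(O)CC(=O)O[C@H](CC=C(C)C)C1=CC(=O)c2c(O)ccc(O)c2C1=O` carries a (2-hydroxy-2-methylbutyl)carbonyl on an oxygen on a saturated carbon of the shared core; in a functional assay on DU-145 cells (Homo sapiens) for cytotoxicity, read by MTT assay (a lower number here means a stronger inhibitor, a higher number a weaker inhibitor), compound 3 gives 20500 nM, the lowest of the two numbers in hand. Its nearest neighbour is compound 1 `CC(C)=CC[C@@H](OC[C@H](C)O)C1=CC(=O)c2c(O)ccc(O)c2C1=O`, which in this assay gives 24500 nM; the step of a 1.2-fold lower number from compound 1 to compound 3 (0.08 log units; within the scatter) lies within the scatter, so the two cannot be ordered. Compound 2 `CCCC(O)CC(=O)O[C@H](CC=C(C)C)C1=CC(=O)c2c(O)ccc(O)c2C1=O` is reported only as a limit in this assay, > 100000 nM. From that limit the step of an at least 4.8-fold lower number from compound 2 to compound 3 (0.68 log units; beyond the scatter) and the step of an at least 4.0-fold higher number from compound 1 to compound 2 (0.61 log units; beyond the scatter) are both beyond the scatter (the limit of > 100000 nM in this assay, at which 1 of the 3 values shown sits).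

Compound 4 `CCC(O)CO[C@H](CC=C(C)C)C1=CC(=O)c2c(O)ccc(O)c2C1=O` is not yet measured. The change from compound 3 is 2-hydroxybutyl in place of (2-hydroxy-2-methylbutyl)carbonyl on an oxygen on a saturated carbon. Among the measured compounds shown here, the one measured step that bears on it, from the ether of compound 1 to the ester of compound 3, a 1.2-fold lower number from compound 1 to compound 3 (0.08 log units; within the scatter), was within the scatter, so a return to an ether is expected to move this assay little. For the measured compounds named here, compound 4 differs from compound 1 only by one further carbon in the 2-hydroxybutyl, and no step is in hand for that pair. The expected step is a 1.2-fold higher number from compound 3 to compound 4 (0.09 log units; within the scatter), none beyond the scatter. Compound 4 is therefore estimated at 25000 nM, with a range from 10000 nM to 70000 nM.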

Compound 4, half-maximal inhibitory concentration: 16400 nM
Beside the measured number, compound 4's estimate is 1.5-fold (0.18 log units) above it, within the range that was stated.
By their numbers in this assay, from the lowest: compounds 4, 3 and 1 (each within the scatter of the next). At a limit, above all of these: compound 2.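

In this assay, among the compounds shown here, a second exchange of ester for ether at this oxygen on a saturated carbon, 2-hydroxybutyl in place of (2-hydroxy-2-methylbutyl)carbonyl, gives a 1.3-fold lower number from compound 3 to compound 4 (0.10 log units; within the scatter), and the first change of chain on the ether side, 1-hydroxypropyl in place of 1-hydroxyethyl, gives a 1.5-fold lower number from compound 1 to compound 4 (0.17 log units; within the scatter), so neither change separates these compounds. The ester of compound 2 goes against any reading that esters and ethers at this oxygen are simply equivalent: 2-hydroxybutyl in place of (2-hydroxypentyl)carbonyl gives an at least 6.0-fold lower number from compound 2 to compound 4 (0.78 log units; beyond the scatter), so the ester side chain matters here, as compound 3 shows by staying level with the ethers. The reading for compound 2 is a limit, and that step is a bound and not a measured size: the limit of > 100000 nM in this assay, at which 1 of the 4 values shown sits.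

Going by these compounds, whether a butyl chain without the hydroxyl, a longer chain than 2-hydroxybutyl, or an amine or a carboxylic acid on this oxygen would move the number beyond the scatter stays open. On these data alone, the hydroxyl-bearing carbon of the chain in compound 4 has no defined stereochemistry, so any role of that centre also remains open.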